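The source may hold more compounds than are shown below. What is called first, only, known or untested is meant among the compounds shown, and "the series" means these compounds.

Measured so far:
- compound 1 `CCC(=O)c1ccc2oc(CS(=O)(=O)c3nnc(CNc4ccccc4)n3CC)nc2c1`: 44%
- compound 2 `CCn1c(CNc2ccccc2)nnc1SCc1nc2cc(F)ccc2o1`: "not determined" (no result reported)
- compound 3 `CCn1c(CNc2ccccc2)nnc1SCc1nc2cc(C)ccc2o1`: "not determined" (no result reported)

In an ADME assay on blood (Rattus norvegicus) for metabolic stability, with a stated time of 2 h (on this read-out higher numbers stand for a more stable compound and lower numbers for a less stable compound), compound 3 has no number, its entry reading "not determined" (no result reported). Within the data shown here, the only number belongs to compound 1, at 44%, and compound 1 differs from compound 3 in more than one place.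

Compound 4 `CCn1c(CNc2ccccc2)nnc1SCc1nc2cc(Cl)ccc2o1` is still unmeasured. It carries chloro in place of methyl on an aromatic carbon. Among the measured compounds shown here, no measured step shows what such a swap does, so no step beyond the scatter is expected in this assay, though this cannot be checked against compound 3. Compound 4 is expected at 60%, with an estimated range of 25% to 95%.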

Compound 4, percent of the compound remaining: 92%
Beside the measured number, compound 4's estimate is 32 percentage points below it, and the stated range covers the measured number.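

Among these compounds, compound 3 has no single number, so no step to compound 4 at 92% can be read in this assay for this pair. Nothing shown accounts for that value. The compounds shown leave open what chloro in place of methyl does to stability on this read-out.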